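The compounds below may be only part of what the source reports. "The series", "measured", "known", "first", "only" and "open" are said of these compounds alone.

Notes on the series. Two compounds have been run in a functional assay on the whole organism for inhibition, with Rattus norvegicus as the target, read by paw edema, in the formalin test, with a stated time of 24 h, at a dose of 100 mg/kg by the intraperitoneal route; on this read-out lower numbers stand for less inhibition and higher numbers for more inhibition at the one dose given (going by the name of the read-out). Compound 1 `O=c1cc(CNc2nc(-c3cc4cc(Br)cc(Br)c4oc3=O)cs2)c2cc(Cl)ccc2[nH]1` gives 9.35% in this assay. Compound 2 `O=c1cc(CNc2nc(-c3cc4cc(Br)cc(Br)c4oc3=O)cs2)c2ccc(Cl)cc2[nH]1` gives 10.6% in this assay. Among the measured compounds shown here, compound 2 is the point of reference here; its number and that of compound 1 differ by less than the scatter, so neither is set apart from the other, and no structural step between measured compounds is recorded.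

The next compound is compound 3 `O=c1cc(CNc2nc(-c3cc4cc(Br)ccc4oc3=O)cs2)c2ccc(Cl)cc2[nH]1`. Its difference from compound 2 is hydrogen in place of bromo on an aromatic carbon. For the measured compounds named here, no measured pair shows the effect of removing a bromo group from this ring, so the expectation rests only on the two numbers in hand, both of which are low. The step expected from this change is a number 0.6 percentage points lower from compound 2 to compound 3 (within the scatter), no step beyond the scatter in either direction. Compound 3 is therefore estimated at 10% in this assay, with a range from 2% to 20%.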

Compound 3, a percentage reported as inhibition, in the whole organism at one dose (the size of the read-out at that dose, not a potency): 18.4%
For compound 3 the middle estimate is 8.4 percentage points below the measured one; measured number inside the range.
By their numbers in this assay, from the lowest: compounds 1, 2 and 3 (each within the scatter of the next).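

In this assay, hydrogen in place of bromo on this aromatic carbon, ortho to a fused ring and meta to a bromo group, gives a number 7.8 percentage points higher from compound 2 to compound 3 (within the scatter), so this single change does not set compound 3 apart from compound 2. Among the compounds shown here, this is the first one-place comparison, and it shows that the read-out at the one dose given does not depend measurably on having bromo rather than hydrogen at this carbon. No measurement in hand bears on the reason for the size of this step.

Still open, going by these compounds, is how an amine, a methoxy group or a carboxylic acid on this carbon would read. Also open, on these data alone, is whether hydrogen in place of the remaining bromo group would give a step beyond the scatter.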